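Methoxy to difluoro swap on the aryl ketone

The source may report more compounds than this note shows. Statements on the series, on what has been measured and on what is new or still open speak of the compounds shown alone.

Measured so far:
compound 1 `COc1ccc(C(=O)/C=C/c2cc(-c3cc(OC)c(OC)c(OC)c3)n[nH]2)cc1OC` -78%
compound 2 `COc1ccc(C(=O)/C=C/c2cc(-c3cc(OC)c(OC)c(OC)c3)n[nH]2)cc1` -41%

In a functional assay on HCT-15 cells (Homo sapiens) for cytotoxicity, read by sulforhodamine B assay, with a stated time of 48 h, tested at 10 uM (on this read-out lower numbers stand for a stronger effect and higher numbers for a weaker effect at the one concentration tested), compound 2 gives the higher of the two numbers, with compound 1 below it by a number 37 percentage points higher from compound 1 to compound 2 (beyond the scatter). Compound 3 `COc1cc(-c2cc(/C=C/C(=O)c3ccc(F)c(F)c3)[nH]n2)cc(OC)c1OC` is not yet measured; it differs from compound 2 by 3,4-difluorophenyl in place of 4-methoxyphenyl on a carbonyl carbon. Among the measured compounds shown here, no measured step covers this exchange, but the one step on the same ring, a number 37 percentage points higher from compound 1 to compound 2 (beyond the scatter), was large and upward. Compound 3 is therefore expected to move up by a number 19 percentage points higher from compound 2 to compound 3 (beyond the scatter) or stay within scatter. The estimate for compound 3 is -22%, ranging from -60% to 10%.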

Compound 3, a percentage reported as activity, at one concentration (the size of the read-out at that concentration, not a potency): 9%
For compound 3 the middle estimate is 31 percentage points below the measured one, and the stated range covers the measured number.
By their numbers in this assay, from the lowest: compound 1; then compound 2; then compound 3.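

On the carbonyl carbon, 3,4-difluorophenyl in place of 4-methoxyphenyl gives a number 50 percentage points higher from compound 2 to compound 3 (beyond the scatter) in this assay, and in place of 3,4-dimethoxyphenyl it gives a number 87 percentage points higher from compound 1 to compound 3 (beyond the scatter). The effect at this position can therefore weaken much further than the loss of one methoxy group showed, and compound 3, at 9%, is the weakest of the three. No available evidence explains this change. The compounds shown leave open whether the two fluorines or the missing methoxy groups set the size of these steps, and how a hydroxyl group or an amine on this ring would read.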